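The source may report more compounds than this note shows. Statements on the series, on what has been measured and on what is new or still open speak of the compounds shown alone.

Working notes on the series.

Of the compounds shown here, two have numbers so far: compound 1 `COc1cc(-c2cc(/C=C/C(=O)c3ccc(N)cc3)[nH]n2)cc(OC)c1OC` and compound 2 `COc1cc(-c2cc(/C=C/C(=O)c3ccc(Cl)c(Cl)c3)[nH]n2)cc(OC)c1OC`. In a functional assay on SF-539 cells (Homo sapiens) for cytotoxicity, read by sulforhodamine B assay, with a stated time of 48 h, tested at 0.1 uM (on this read-out higher numbers stand for a weaker effect at the one concentration tested and lower numbers for a stronger effect), compound 1 gives 99%, and compound 2 gives 94%. Within the data shown here, the one step between them, a number 5 percentage points lower from compound 1 to compound 2 (within the scatter), replaces 4-aminophenyl with 3,4-dichlorophenyl on the carbonyl carbon. Among the measured compounds shown here, compound 2 therefore holds the lowest of the two numbers in this assay, with compound 1 as its only neighbour, the gap between them within the scatter.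

The next compound, compound 3 `COc1ccc(C(=O)/C=C/c2cc(-c3cc(OC)c(OC)c(OC)c3)n[nH]2)cc1OC`, is obtained from compound 2 by a change at the same position: 3,4-dimethoxyphenyl in place of 3,4-dichlorophenyl on a carbonyl carbon. For the measured compounds named here, the sole step that bears on it is the earlier aryl swap on the carbonyl carbon, which stayed within the scatter, so no movement beyond the scatter is expected in this assay. The expected step is a number 1 percentage points lower from compound 2 to compound 3 (within the scatter). For compound 3 in this assay the estimate is 93%, with a range from 80% to 100%.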

Compound 3, a percentage reported as activity, at one concentration (the size of the read-out at that concentration, not a potency): 98%
Beside the measured number, compound 3's estimate is 5 percentage points below it; the measured number falls inside the stated range.
By their numbers in this assay, from the lowest: compounds 2, 3 and 1 (each within the scatter of the next).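

In this assay the third aryl group on the carbonyl carbon adds no separation: 3,4-dimethoxyphenyl reads the same as 3,4-dichlorophenyl within the scatter (a number 4 percentage points higher from compound 2 to compound 3 (within the scatter)) and the same as 4-aminophenyl within the scatter (a number 1 percentage points lower from compound 1 to compound 3 (within the scatter)). All three groups at this position therefore stand within the scatter of one another at the one concentration tested, and the entry of 2 hydrogen-bond acceptors where 0 left brings no readable difference. No measurement at hand offers an explanation for this absence of separation.

Still open, going by these compounds, is whether a group of another kind on the carbonyl carbon, such as a carboxylic acid or a longer alkyl chain in place of the aryl ring, would separate from these three. The compounds shown also leave open whether the three aryl groups would stay together at any other concentration.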